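Replacing a Branched Alkyl Group with a Cycloalkyl Chain

A few compounds are considered here, and "the series" means these few. Any claim that something is new, unique, unknown or untested is made for them only; others in the source may bear on it.

Three compounds have been measured in a functional assay on the whole organism for inhibition, with Rattus norvegicus as the target, read by paw edema, with stated times of 1 h and 3 h, at a dose of 50 mg/kg by the oral route; a lower number here means less inhibition, a higher number more inhibition at the dose given (going by the name of the read-out):
- compound 1 `C/C(=N\OCC(=O)O)c1ccccc1`, which gives < 20%, a limit of the assay rather than a number.
- compound 2 `C/C(=N\OCC(=O)O)c1ccc(C)cc1`, which gives 20%.
- compound 3 `C/C(=N\OCC(=O)O)c1ccc(C(C)(C)C)cc1`, which gives < 20%, again only a limit of the assay.

Compound 3 therefore stands at the low end of what this assay can report, and the limit of < 20% in this assay, at which 2 of the 3 values shown sit, shows that it shares this position with one other compound. The measured steps carry little information: a step that the two limits leave unreadable from compound 1 to compound 3, and a number no higher from compound 2 to compound 3 (the limit leaves the size open). Only a number no lower from compound 1 to compound 2 (the limit leaves the size open) is readable in direction, and even that step is open in size.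

Compound 4 `C/C(=N\OCC(=O)O)c1ccc(CC2CCCCC2)cc1` is built from compound 3 by the change (cyclohexylmethyl in place of tert-butyl on an aromatic carbon). For the measured compounds named here, no measured step involves a cyclohexylmethyl group, so the expectation rests on the three low values around compound 3. The step from compound 3 to compound 4 is expected to be a number no lower from compound 3 to compound 4 (the limit leaves the size open), with no clear movement beyond the scatter. Compound 4 is estimated at 20%, within a range from 5% to 40%.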

Compound 4, a percentage reported as inhibition, in the whole organism at one dose (the size of the read-out at that dose, not a potency): < 20%
Compound 4: no number, only a limit; the forecaster's own chance of this, stated with the estimate: 50%; the middle value lies on the limit itself.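

A ring-bearing chain at this place, with cyclohexylmethyl in place of tert-butyl, still leaves the read-out at the bottom of what can be reported, so the low end now holds a third compound: the limit of < 20% in this assay, at which 3 of the 4 values shown sit. For the compounds shown here, the only new step with a readable direction is a number no higher from compound 2 to compound 4 (the limit leaves the size open). The other two new steps join one limit to another and cannot be read.

Going by these compounds, how far compound 1, compound 3 and compound 4 actually lie under the limit stays open, so these three cannot be ranked against each other. Also open, on these data alone, is whether a methoxy group or a chlorine atom at this place would give a clearly higher read-out in this assay.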